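The source may hold more compounds than are shown below. What is called first, only, known or untested is meant among the compounds shown, and "the series" means these compounds.

Compound 2 `O=C1C(Nc2ccccc2)=CC(=O)c2c1nc1n2[C@H]2OC[C@@H](O)[C@H]2OC1` and compound 1 `O=C1C(Nc2ccc(I)cc2)=CC(=O)c2c1nc1n2[C@H]2OC[C@@H](O)[C@H]2OC1` share one core, on which an anilino group carries either hydrogen or iodo. In a functional assay on HeLa cells (Homo sapiens) for inhibition, read by sulforhodamine B assay (on this read-out lower numbers stand for stronger inhibition and higher numbers for weaker inhibition), compound 1 gives 4010 nM. For compound 2 this assay reports only a limit, > 8000 nM. The change iodo in place of hydrogen on an aromatic carbon thus produced an at least 1.9-fold lower number from compound 2 to compound 1 (0.29 log units; that floor lies within the scatter), a floor sitting at the limit of > 8000 nM in this assay, at which 1 of the 3 values shown sits. Compound 3 `O=C1C=C(Nc2ccccc2)C(=O)c2c1nc1n2[C@H]2OC[C@@H](O)[C@H]2OC1` has the same atoms as compound 2 joined differently; the difference between the two cores is not broken down here. In this assay compound 3 gives 5620 nM. Compound 4 `O=C1C=C(Nc2ccc(I)cc2)C(=O)c2c1nc1n2[C@H]2OC[C@@H](O)[C@H]2OC1` stands to compound 3 as compound 1 stands to compound 2, through (iodo in place of hydrogen on an aromatic carbon), the same change at the same place. Resting on compound 2 and the step of an at least 1.9-fold lower number from compound 2 to compound 1 (0.29 log units; that floor lies within the scatter), a step of about a 1.9-fold lower number from compound 3 to compound 4 (0.27 log units; within the scatter) is expected. Compound 4 is therefore estimated at 3000 nM, between 1200 nM and 7000 nM.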

Compound 4, half-maximal inhibitory concentration: 4070 nM
Beside the measured number, compound 4's estimate is 1.4-fold (0.13 log units) below it; the measured number falls inside the stated range.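

On the second core, the change of phenyl to 4-iodophenyl gives a 1.4-fold lower number from compound 3 to compound 4 (0.14 log units; within the scatter) in this assay. Compound 2 carries only a limit of the assay, > 8000 nM, and not a number. Set side by side, the two steps show no conflict between the cores, but they do not show that the change carries over at equal size: the same change on two cores in this assay, an at least 1.9-fold lower number (0.29 log units; that floor lies within the scatter) from compound 2 to compound 1 and a 1.4-fold lower number (0.14 log units; within the scatter) from compound 3 to compound 4; the limit leaves it open whether they differ

The compounds shown leave open whether a group other than iodo at that place, such as bromo, methoxy or an amine, would move the number on either core beyond the scatter. They also leave open whether a carboxylic acid there would act alike on the two cores.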